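The source may hold more compounds than are shown below. What is called first, only, known or untested is meant among the compounds shown, and "the series" means these compounds.

For the measured compounds named here, compound 2, `C[C@H](NC(=O)[C@H](CCCNC(=N)N)NC(=O)c1ccc(CN(Cc2ccncc2)Cc2ccc(F)cc2)cc1)c1cccc2ccccc12`, is one of two compounds measured in an ADME assay on MT4 cells (Homo sapiens) for cytotoxicity (a higher number here means that more compound is tolerated, a lower number that less compound is tolerated), and there it gives 44000 nM, the higher of the two numbers. Going by the values given here, its only measured neighbour is compound 1, `C[C@H](NC(=O)[C@H](CCCNC(=N)N)NC(=O)c1ccc(CN(Cc2ccc(F)cc2)Cc2ccccn2)cc1)c1cccc2ccccc12`, which in this assay gives 11000 nM; the single measured step, a 4.0-fold higher number from compound 1 to compound 2 (0.60 log units; beyond the scatter), came from changing one pyridyl for another on a saturated chain carbon bound to the amine nitrogen. Compound 3, `C[C@H](NC(=O)[C@H](CCCNC(=N)N)NC(=O)c1ccc(CN(Cc2ccncc2)C(=O)c2ccc(F)cc2)cc1)c1cccc2ccccc12`, differs from compound 2 in a different way: (4-fluorophenyl)carbonyl in place of 4-fluorobenzyl on an amine nitrogen, so the amine nitrogen of compound 2 becomes an amide nitrogen in compound 3. Among the compounds with values here, no measured step touches this change; the only step known concerns the pyridyl substituent and leaves the 4-fluorobenzyl untouched. With nothing to lean on, the step from compound 2 to compound 3 in this assay is expected to stay within the scatter, no change at the digits printed from compound 2 to compound 3 (within the scatter), while the range is kept wide. For compound 3 the estimate in this assay is therefore 44000 nM, between 15000 nM and 130000 nM.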

Compound 3, half-maximal cytotoxic concentration: 51000 nM
Compound 3: middle estimate off by 1.2-fold (0.06 log units), on the low side, within the range that was stated.
By their numbers in this assay, from the lowest: compound 1; then compounds 2 and 3 (each within the scatter of the next).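

In this assay the exchange on the amine nitrogen whose other neighbours are two saturated chain carbons gives a 1.2-fold higher number from compound 2 to compound 3 (0.06 log units; within the scatter), so (4-fluorophenyl)carbonyl in place of 4-fluorobenzyl, which turns that amine nitrogen into an amide nitrogen and brings in one hydrogen-bond acceptor, leaves the read-out without a change beyond the scatter. For the compounds shown here, the earlier pair showed a difference only at the pyridyl group, a 4.0-fold higher number from compound 1 to compound 2 (0.60 log units; beyond the scatter), with the 4-fluorobenzyl held fixed, so this result is the only reading of a change at the 4-fluorobenzyl group, and in this one compound pair that group can be exchanged for the carbonyl-linked one with no readable shift. No evidence at hand accounts for this outcome.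

Going by these compounds, whether the same exchange holds with pyridin-2-yl, the group carried by compound 1, stays open, as the amide nitrogen is seen here only in a compound carrying pyridin-4-yl. Also open, on these data alone, is how a methanesulfonyl group or a plain methyl on that nitrogen in place of 4-fluorobenzyl would read in this assay.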